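The compounds below may be only part of what the source reports. "The series", "measured", "known", "first", "only" and "open" are said of these compounds alone.

Compound 1 `N#CC1=C(NCN2CCCCC2)N(c2ccccc2)C(=O)N2CCCCC(N3CCCC3)C12` is the weakest of the three measured compounds in a functional assay on the whole organism (strain albino) for inhibition, with Rattus norvegicus as the target, read by paw edema, with stated times of 1 h and 3 h, at a dose of 20 mmol/kg by the intraperitoneal route (a lower number here means a weaker effect, a higher number a stronger effect of the compound at the dose given), where compound 1 gives 42.1%. Compound 2 `N#CC1=C(/N=C/Nc2ccc([N+](=O)[O-])cc2)N(c2ccccc2)C(=O)N2CCCCC(N3CCCC3)C12` gives 85.6% in this assay, and compound 3 `N#Cc1c2n(c(=O)n(-c3ccccc3)c1=N)CCCCC2N1CCCC1` gives 93.4%. For the measured compounds named here, the only single-point change among the measured compounds is the one from compound 1 to compound 2, where the step was a number 43.5 percentage points higher from compound 1 to compound 2 (beyond the scatter).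

Compound 4 `N#CC1=C(/N=C/Nc2ccccc2)N(c2ccccc2)C(=O)N2CCCCC(N3CCCC3)C12` is not yet measured. It differs from compound 1 as follows: a group of 9 heavy atoms (7 carbon, 2 nitrogen; one six-membered aromatic ring of carbon only) in place of a group of 8 heavy atoms (6 carbon, 2 nitrogen; one six-membered non-aromatic ring with 1 hetero atom), on a double-bonded ring carbon. Going by the values given here, the group entering compound 4 resembles the group entering compound 2, both being aryl-bearing groups attached through a double bond outside aromatic rings, and the group leaving is the same in both cases, so the step from compound 1 to compound 2 is the one that bears on compound 4. Among the compounds with values here, on that basis a large rise in this assay is expected for compound 4, on the order of a number 35.9 percentage points higher from compound 1 to compound 4 (beyond the scatter), though with no measured step isolating the difference between the two entering groups the size is uncertain. Compound 4 is therefore estimated at 78%, within a range from 60% to 92%.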

Compound 4, a percentage reported as inhibition, in the whole organism at one dose (the size of the read-out at that dose, not a potency): 79.3%
The estimate for compound 4 lay 1.3 percentage points below the measured number, and the stated range covers the measured number.
By their numbers in this assay, from the lowest: compound 1; then compounds 4, 2 and 3 (each within the scatter of the next, the first and the last beyond it).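

In this assay, the gain at this double-bonded ring carbon does not depend on the nitro group: exchanging ((piperidin-1-yl)methyl)amino for the unsubstituted phenyl-bearing group gives a number 37.2 percentage points higher from compound 1 to compound 4 (beyond the scatter) on its own. Hydrogen in place of nitro on the aromatic carbon gives a number 6.3 percentage points lower from compound 2 to compound 4 (within the scatter), so the two aryl-bearing groups cannot be told apart here, and the large rise goes with the exchange of the group on the ring carbon, not with the nitro group. No measurement shown gives a reason for either step.

From the compounds shown here alone, it remains open whether a methoxy group, a chlorine atom or an amine on the same aromatic ring would keep this effect. Going by these compounds, whether a saturated ring such as morpholine in the leaving group's place would behave like ((piperidin-1-yl)methyl)amino also stays unknown.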